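The source may hold more compounds than are shown below. What is called first, only, known or untested is meant among the compounds shown, and "the series" means these compounds.

Measured compounds:
- compound 1 `C=CS(=O)(=O)N1CCN(c2ncnc3sc(-c4ccccc4)cc23)CC1` with 54200 nM
- compound 2 `C=CS(=O)(=O)N1CCN(c2ncnc3sc(-c4ccnc(Cl)c4)cc23)CC1` with 27700 nM

Both values come from a functional assay on MDA-MB-231 cells (Homo sapiens) for antiproliferative activity, read by MTT assay, with a stated time of 48 h (a lower number here means a stronger inhibitor, a higher number a weaker inhibitor), and lie within the scatter of each other, so compound 2 stands level with compound 1 on these numbers. Compound 3 `C=CS(=O)(=O)N1CCN(c2ncnc3sc(-c4cc(Br)cnc4F)cc23)CC1` differs from compound 2 as follows: 5-bromo-2-fluoropyridin-3-yl in place of 2-chloropyridin-4-yl on an aromatic carbon with 5-bromo-2-fluoropyridin-3-yl in place of 2-chloropyridin-4-yl on an aromatic carbon next to the ring sulfur. Within the data shown here, one measured step bears on this place: a 2.0-fold lower number from compound 1 to compound 2 (0.29 log units; within the scatter) stays within the scatter. No step beyond the scatter is therefore expected in this assay and no direction can be given. The expected size is a 1.1-fold lower number from compound 2 to compound 3 (0.04 log units; within the scatter) as an estimate. The estimated value for compound 3 is 25000 nM with an expected range from 10000 nM to 60000 nM overall.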

Compound 3, half-maximal inhibitory concentration: 24100 nM
Compound 3: the middle estimate sits 1.0-fold (0.02 log units) above what was measured; low and high end bracket the measured number.
By their numbers in this assay, from the lowest: compounds 3, 2 and 1 (each within the scatter of the next, the first and the last beyond it).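

In this assay, the aromatic carbon next to the ring sulfur accepts 5-bromo-2-fluoropyridin-3-yl as readily as 2-chloropyridin-4-yl, with a 1.1-fold lower number from compound 2 to compound 3 (0.06 log units; within the scatter) showing no separation between the two substituted pyridines. Among these compounds, measured against phenyl, the same group gives a 2.2-fold lower number from compound 1 to compound 3 (0.35 log units; beyond the scatter), the first step at this position to clear the scatter, though only modestly. Nothing available explains either step. As far as these compounds go, all three compounds carry an aromatic ring at this place, so it remains open how a morpholine or a carboxylic acid there would read.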